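This account rests on a few compounds, and the source may have more. Where it says the series, first, only, none or still open, it means among the compounds named here.

Working notes on the series. Within the data shown here, in a functional assay on T47D cells (Homo sapiens) for inhibition, read by sulforhodamine B assay, with a stated time of 48 h, tested at 10 uM (on this read-out lower numbers stand for less inhibition and higher numbers for more inhibition at the one concentration tested (going by the name of the read-out)), compound 3 `c1cn2cc(-c3ccsc3)nc(-c3ccc4ncn(C5CCCCC5)c4c3)c2n1` gives 63.7%, the highest of the three numbers so far. Compound 1 `Brc1cn2ccnc2c(-c2ccc3ncn(C4CCCCC4)c3c2)n1` gives 49.7% in this assay, and a number 14 percentage points higher from compound 1 to compound 3 (beyond the scatter). Compound 2 `COc1ccc(-c2cn3ccnc3c(-c3ccc4ncn(C5CCCCC5)c4c3)n2)cc1` gives -8.6% in this assay, and a number 72.3 percentage points higher from compound 2 to compound 3 (beyond the scatter); the remaining measured step is a number 58.3 percentage points lower from compound 1 to compound 2 (beyond the scatter).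

Compound 4 `CC(=O)c1ccc(-c2cn3ccnc3c(-c3ccc4ncn(C5CCCCC5)c4c3)n2)cc1` has not yet been measured. It differs from compound 3 in one place: 4-acetylphenyl in place of thiophen-3-yl on an aromatic carbon.

The step that bears most directly on this change runs the other way, a number 72.3 percentage points higher from compound 2 to compound 3 (beyond the scatter), with thiophen-3-yl in place of 4-methoxyphenyl. Among the measured compounds shown here, compound 4 instead carries 4-acetylphenyl, so no measured step compares the acetyl and methoxy cases, and the size of the expected drop is uncertain. A large downward step in this assay is nonetheless expected, estimated as a number 48.7 percentage points lower from compound 3 to compound 4 (beyond the scatter). For compound 4 the expected number in this assay is 15%, with a range from -15% to 50%.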

Compound 4, a percentage reported as inhibition, at one concentration (the size of the read-out at that concentration, not a potency): 54.4%
Beside the measured number, compound 4's estimate is 39.4 percentage points below it; measured number outside the range, above it.
By their numbers in this assay, from the lowest: compound 2; then compounds 1, 4 and 3 (each within the scatter of the next, the first and the last beyond it).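

A phenyl ring at this position does not by itself carry the very low number of compound 2: in this assay, acetyl in place of methoxy on that ring gives a number 63 percentage points higher from compound 2 to compound 4 (beyond the scatter) and so separates the two substituted phenyl compounds. The larger 4-acetylphenyl also stays level with both smaller groups, with a number 9.3 percentage points lower from compound 3 to compound 4 (within the scatter) for thiophen-3-yl and a number 4.7 percentage points higher from compound 1 to compound 4 (within the scatter) for bromo, so compound 4 cannot be ordered against compound 1 or compound 3. No evidence bears on why the methoxy and acetyl compounds part so widely.

Among these compounds, whether the low number is peculiar to methoxy remains open, since only two groups on the phenyl ring can be compared. An amine or a carboxylic acid in place of the acetyl would show whether the number in this assay stays level or turns lower.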